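Same Ring Swap, Tested Again on a Second Core

This account rests on a few compounds, and the source may have more. Where it says the series, first, only, none or still open, it means among the compounds named here.

Compound 1 `CCOC(=O)/C=C/[C@H](CC(C)C)NC(=O)[C@H](CC(C)C)NC(=O)[C@H](CC(C)C)NC(=O)C1=CCCNC1` was tested in an ADME assay for metabolic stability, in the presence of a further agent that is not named here; a higher number here means that the compound lasts longer, a lower number that the compound disappears faster. In this assay compound 1 gives > 6 h, which is a limit of the measurement and not a number. Compound 2 `CCOC(=O)/C=C/[C@H](CC(C)C)NC(=O)[C@H](CC(C)C)NC(=O)[C@H](CC(C)C)NC(=O)c1cccc(O)c1C` differs from compound 1 in one place: a group of 8 heavy atoms (7 carbon, 1 oxygen; one six-membered aromatic ring of carbon only) in place of a group of 6 heavy atoms (5 carbon, 1 nitrogen; one six-membered non-aromatic ring with 1 hetero atom), on a carbonyl carbon. In this assay compound 2 also gives > 6 h, again a limit. The step that the two limits leave unreadable from compound 1 to compound 2 cannot be sized because of the limit of > 6 h in this assay, at which 3 of the 3 values shown sit.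

Compound 3 `CCOC(=O)/C=C/[C@H](CC(C)C)NC(=O)[C@H](CO)NC(=O)[C@@H](NC(=O)C1=CCCNC1)C(C)C` has a different core; how its core differs from that of compound 1 is not broken down here. In this assay compound 3 gives > 6 h, once more a limit.

Compound 4 `CCOC(=O)/C=C/[C@H](CC(C)C)NC(=O)[C@H](CO)NC(=O)[C@@H](NC(=O)c1cccc(O)c1C)C(C)C` has not been measured. Among the measured compounds shown here, it differs from compound 3 by a group of 8 heavy atoms (7 carbon, 1 oxygen; one six-membered aromatic ring of carbon only) in place of a group of 6 heavy atoms (5 carbon, 1 nitrogen; one six-membered non-aromatic ring with 1 hetero atom), on a carbonyl carbon, the same change as the one from compound 1 to compound 2. The step that the limit leaves unreadable from compound 3 to compound 4 is the expected size, kept flat because the limit of > 6 h in this assay, at which 3 of the 3 values shown sit, shows the earlier instance left both compound 1 and compound 2 at the limit. Compound 4 is therefore expected to give 8 h in this assay, most likely reported only as a limit, with a range of 4 h to 20 h.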

Compound 4, half-life: > 6 h
Compound 4 was reported as a limit (the forecaster's own chance of this, stated with the estimate: 85%); the middle value does not contradict the limit.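

No size can be read for the change from compound 3 to compound 4, because both results are limits of the measurement and not numbers: the limit of > 6 h in this assay, at which 4 of the 4 values shown sit.

The compounds shown leave open how long any of them really lasts in this assay, and so whether this ring swap changes that on either core.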